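The source may report more compounds than this note shows. Statements on the series, on what has been measured and on what is new or still open speak of the compounds shown alone.

Compound 1 `COc1ccc(CNCc2c(OC)cc(Oc3cccc(Nc4ccccc4)c3)cc2OC)cc1` gives 1910 nM in a functional assay on DLD-1 cells (Homo sapiens) for inhibition, read by MTT assay, with a stated time of 72 h; on this read-out lower numbers stand for stronger inhibition and higher numbers for weaker inhibition. Compound 2 `COc1cc(Oc2cccc(Nc3ccccc3)c2)cc(OC)c1CNCc1ccc(C)cc1` differs from it in one place, a methyl in place of a methoxy on an aromatic carbon, and gives 6080 nM; that move reads as a 3.2-fold higher number from compound 1 to compound 2 (0.50 log units; beyond the scatter). Among the two numbers so far, compound 2 stands highest, its nearest neighbour being compound 1.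

Compound 3 `CCN1CCN(Cc2c(OC)cc(Oc3cccc(Nc4ccccc4)c3)cc2OC)CC1` is the next compound, and its change from compound 2 is 4-ethylpiperazin-1-yl in place of (4-methylbenzyl)amino on a saturated chain carbon bound to an aromatic carbon. Going by the values given here, the only measured step concerns an exchange on an aromatic carbon and leaves the benzylamine part untouched, so no measured step bears on this replacement of the whole side group by a ring. The direction of the effect cannot be read from the two numbers in hand. The expectation for compound 3 is therefore a number near that of compound 2, with a wide band of uncertainty, amounting to an expected step of a 1.2-fold lower number from compound 2 to compound 3 (0.08 log units; within the scatter). Compound 3 is estimated at 5000 nM, in a range from 1200 nM to 20000 nM.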

Compound 3, half-maximal inhibitory concentration: > 20000 nM
Compound 3 gave a limit, no number; the forecaster's own chance of this, stated with the estimate: 10%; at least 4.0-fold (0.60 log units) between middle value and limit.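

Going by these compounds alone, this is the first change to the whole side group on the saturated chain carbon bound to an aromatic carbon, and putting 4-ethylpiperazin-1-yl in place of (4-methylbenzyl)amino gives an at least 3.2-fold higher number from compound 2 to compound 3 (0.51 log units; beyond the scatter). Against the (4-methoxybenzyl)amino group the same replacement gives an at least 10-fold higher number from compound 1 to compound 3 (1.01 log units; beyond the scatter), a larger gap than the one the methyl and methoxy exchange opened, so inhibition depends strongly on what sits at this place. In this assay compound 3 gives a limit and not a number: the limit of > 20000 nM in this assay, at which 1 of the 3 values shown sits.

The benzene ring and the amine hydrogen leave together, and the compounds shown do not separate the two. From the compounds shown here alone, how a morpholine ring, or a 4-methylbenzyl group carried on a piperazine ring, would read at this place stays open.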